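The source may hold more compounds than are shown below. What is called first, only, known or untested is meant among the compounds shown, and "the series" means these compounds.

Compound 3 `COc1ccc(CNC(=O)/C(C#N)=C/c2cc(Br)co2)cc1` is measured in a functional assay on SJ-G2 cells (Homo sapiens) for inhibition, read by MTT assay, with a stated time of 72 h (on this read-out higher numbers stand for weaker inhibition of growth and lower numbers for stronger inhibition of growth), at 23000 nM. Among the compounds with values here, that is the lowest of the two numbers known, with compound 2 `COc1ccc(CNC(=O)/C(C#N)=C/c2ccco2)cc1` nearest at 31000 nM, a gap within the scatter. Compound 1 `COc1ccc(CNC(=O)/C(C#N)=C/c2ccc[nH]2)cc1` gives only a limit, > 50000 nM. Compound 4 `COc1ccc(CNC(=O)/C(C#N)=C/c2ccoc2)cc1` differs from compound 3 by furan-3-yl in place of 4-bromofuran-2-yl on a double-bonded chain carbon bound to a double-bonded chain carbon. Within the data shown here, the one measured step that touches the bromine, a 1.3-fold lower number from compound 2 to compound 3 (0.13 log units; within the scatter), was within the scatter; the ring swaps an at least 1.6-fold lower number from compound 1 to compound 2 (0.20 log units; that floor lies within the scatter) and an at least 2.1-fold lower number from compound 1 to compound 3 (0.33 log units; beyond the scatter) start from a limit and compare different rings, so they say little about a shift of the attachment point. Compound 4 is therefore expected to show a step of a 1.2-fold higher number from compound 3 to compound 4 (0.09 log units; within the scatter) in this assay, none beyond the scatter. For compound 4 the estimated value is 28000 nM, expected between 12000 nM and 65000 nM.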

Compound 4, concentration for 50% growth inhibition: 8000 nM
Compound 4: the middle estimate sits 3.5-fold (0.54 log units) above what was measured, outside the stated range (below it).
By their numbers in this assay, from the lowest: compound 4; then compounds 3 and 2 (each within the scatter of the next). At a limit, above all of these: compound 1.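

In this assay, within the data shown here, shifting the attachment point of the unsubstituted furan gives a 3.9-fold lower number from compound 2 to compound 4 (0.59 log units; beyond the scatter), the first change at this position that rests on two measured numbers and lies beyond the scatter. Furan-3-yl in place of 4-bromofuran-2-yl gives a 2.9-fold lower number from compound 3 to compound 4 (0.46 log units; beyond the scatter), whereas adding the bromo alone stayed within the scatter. The third step, an at least 6.2-fold lower number from compound 1 to compound 4 (0.79 log units; beyond the scatter), is only a floor, set by a limit: the limit of > 50000 nM in this assay, at which 1 of the 4 values shown sits.

As far as these compounds go, whether a bromo on the furan-3-yl ring would move the number further remains open. So does the effect of an amine or a carboxylic acid on that ring.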